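Bromo for chloro in the oxime series: second instance

The source may report more compounds than this note shows. Statements on the series, on what has been measured and on what is new or still open speak of the compounds shown alone.

Of the compounds shown here, three measured so far share an oxime attached to a vinyl link between two aromatic rings. Compound 1 `O/N=C(\C=C\c1ccc(F)cc1)c1ccc(Cl)cc1` gives 10600 nM in a functional assay (Mus musculus, strain Balb/c) for inhibition, read by ELISA, with a stated time of 72 h; a higher number here means a weaker inhibitor, a lower number a stronger inhibitor. Compound 2 `O/N=C(\C=C\c1ccc(F)cc1)c1ccc(Br)cc1` gives 13300 nM in this assay. Compound 3 `Cc1ccc(C(/C=C/c2ccc(Cl)cc2)=N/O)cc1` gives 11600 nM in this assay. The difference between the core of compound 1 and the core of compound 3 is not broken down here; their values in this assay sit within the scatter of each other.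

Among the measured compounds shown here, the one counted change from compound 1 to compound 2 is bromo in place of chloro on an aromatic carbon, and it made a 1.3-fold higher number from compound 1 to compound 2 (0.10 log units; within the scatter). Compound 4 `Cc1ccc(C(/C=C/c2ccc(Br)cc2)=N/O)cc1` has not yet been measured. It differs from compound 3 by bromo in place of chloro on an aromatic carbon, the same change at a place described in the same words. For the measured compounds named here, the expectation for compound 4 in this assay is therefore a step like the earlier one, a 1.2-fold higher number from compound 3 to compound 4 (0.07 log units; within the scatter), because the one measured instance, a 1.3-fold higher number from compound 1 to compound 2 (0.10 log units; within the scatter), stayed within the scatter. Compound 4 is expected at 13500 nM, with a range from 7000 nM to 27000 nM.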

Compound 4, half-maximal inhibitory concentration: 11600 nM
Compound 4: middle estimate off by 1.2-fold (0.07 log units), on the high side; the range from low to high includes it.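

In this assay, bromo in place of chloro on an aromatic carbon gives no change at the digits printed from compound 3 to compound 4 (within the scatter). Set beside the earlier instance, the change carries from one core to the other with no difference that can be told apart: the same change on two cores in this assay, a 1.3-fold higher number (0.10 log units; within the scatter) from compound 1 to compound 2 and no change at the digits printed (within the scatter) from compound 3 to compound 4, 1.3-fold (0.10 log units) apart, within the scatter of two such steps This shows only that, on these two cores and in this one assay, the exchange of the two halogens leaves the number within the scatter; it does not show that the same would hold on any other core in the series, and two pairs of compounds establish no general rule.

The compounds shown leave open whether a group other than these two halogens at that aromatic carbon, such as an amine, a carboxylic acid or a longer chain, would move the number beyond the scatter. They also leave open how the oxime itself bears on the values in this assay, for instance when set against a plain carbonyl on the same core.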